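Pentyl to 4-methylphenyl on the amide: cytotoxicity outlook

This account rests on a few compounds, and the source may have more. Where it says the series, first, only, none or still open, it means among the compounds named here.

Compound 1 `CN(C)c1cc2[nH]c(C3CCCCC3)nc2cc1NC(=O)c1ccc(Br)cc1` gives > 100 ug/mL in an ADME assay on Vero cells (Chlorocebus sabaeus) for cytotoxicity, read by resazurin assay, with a stated time of 3 days (on this read-out higher numbers stand for weaker inhibition and lower numbers for stronger inhibition), which is a limit of the assay and not a number.
Compound 2 `COc1ccc(C(=O)Nc2cc3nc(C4CCCCC4)[nH]c3cc2N(C)C)cc1` gives > 100 ug/mL in this assay, again a limit.
Compound 3 `CCCCCC(=O)Nc1cc2nc(C3CCCCC3)[nH]c2cc1N(C)C` gives > 100 ug/mL in this assay, also a limit.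

Compound 3 therefore stands at the limit of > 100 ug/mL in this assay, at which 3 of the 3 values shown sit, and nothing places it above or below the other two. The steps among the measured compounds, a step that the two limits leave unreadable from compound 1 to compound 2, a step that the two limits leave unreadable from compound 1 to compound 3 and a step that the two limits leave unreadable from compound 2 to compound 3, cannot be sized, since each end sits at a limit; they show only that two amides carrying an aromatic ring on the carbonyl carbon and one carrying a pentyl chain all reach the limit.

Compound 4 `Cc1ccc(C(=O)Nc2cc3nc(C4CCCCC4)[nH]c3cc2N(C)C)cc1` differs from compound 3 by 4-methylphenyl in place of pentyl on a carbonyl carbon. The two ring-bearing measured compounds, compound 1 and compound 2, and the chain-bearing compound 3 are all at the limit, so the step in this assay is expected to be none beyond the scatter, in either direction, with another limit the most likely outcome. Compound 4 is expected to give about 150 ug/mL, in the range 60 ug/mL to 400 ug/mL. The expected step that the limit leaves unreadable from compound 3 to compound 4 is accordingly a small one, within the scatter.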

Compound 4, half-maximal inhibitory concentration: > 100 ug/mL
Compound 4: no number, only a limit; the forecaster's own chance of this, stated with the estimate: 85%; the middle value lies beyond the limit too.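

Like compound 1, compound 2 and compound 3, compound 4 reaches only a limit and not a number, so no step to compound 4 from any of them can be read: the limit of > 100 ug/mL in this assay, at which 4 of the 4 values shown sit.

The compounds shown leave open how far these four lie from one another in this assay, and at what concentration any of them would inhibit the cells by half.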